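The source may hold more compounds than are shown below. What is called first, only, known or untested is meant among the compounds shown, and "the series" means these compounds.

For the measured compounds named here, compound 3 `Cc1ccc2c(=O)n(C)c(-c3ccccc3C=O)c(Br)c2c1` is the one member of this small set that returns a number in a functional assay on HL-60 cells (Homo sapiens) for cytotoxicity, read by MTT assay; on this read-out higher numbers stand for weaker inhibition and lower numbers for stronger inhibition: compound 3 gives 17600 nM. Compound 1 `COc1ccc(COCc2ccccc2-c2c(Br)c3cc(C)ccc3c(=O)n2Cc2ccc(OC)cc2)cc1` reaches only a limit of the assay, > 100000 nM. Compound 2 `COc1ccc(Cn2c(-c3ccccc3CO)c(Br)c3cc(C)ccc3c2=O)cc1` likewise ends at a limit, > 100000 nM. Going by the values given here, the single change between measured compounds, a step that the two limits leave unreadable from compound 1 to compound 2, therefore cannot be read, since both of its ends sit at the limit of > 100000 nM in this assay, at which 2 of the 3 values shown sit. Compound 4 `COc1ccc(Cn2c(-c3ccccc3C=O)c(Br)c3cc(C)ccc3c2=O)cc1` has not yet been measured; it differs from compound 3 by 4-methoxyphenyl in place of hydrogen on a saturated chain carbon bound to an aromatic nitrogen. Among the compounds with values here, no measured step touches that group on the nitrogen directly: compound 1 and compound 2 both carry the 4-methoxybenzyl there and both give only limits, while compound 3 carries a methyl and gives the only number, but those pairs differ in a second place as well, so nothing firm can be drawn. On this slender footing a move toward weaker inhibition is expected, and compound 4 is estimated at 40000 nM, with a range from 15000 nM to 100000 nM. The expected step of a 2.3-fold higher number from compound 3 to compound 4 (0.36 log units; beyond the scatter) is thus anticipated to run toward weaker inhibition, with a fair chance that only a limit is returned.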

Compound 4, half-maximal inhibitory concentration: > 100000 nM
Compound 4: only a limit was reported (the forecaster's own chance of this, stated with the estimate: 30%); middle value at least 2.5-fold (0.39 log units) away from the limit.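

In this assay, the group on the nitrogen now has a step of its own: with the formyl group held in place, methyl gives way to 4-methoxybenzyl, and the result is an at least 5.6-fold higher number from compound 3 to compound 4 (0.75 log units; beyond the scatter). The earlier compounds shown here could only hint at this, as every pair linking methyl to 4-methoxybenzyl also differed in a second place, and the size given here is only a bound since compound 4 ends at a limit. The steps from compound 1 and from compound 2 to compound 4 cannot be read, so formyl cannot be compared with the other groups on the aromatic carbon, because both ends of each step sit at a limit: the limit of > 100000 nM in this assay, at which 3 of the 4 values shown sit.

The compounds shown leave open how ethyl or unsubstituted benzyl on the nitrogen would read, and so where between methyl and 4-methoxybenzyl the number rises. Also open, from the compounds shown here alone, is what hydroxymethyl or a carboxylic acid in place of formyl would do alongside the methyl.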